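The source may hold more compounds than are shown below. What is called first, only, known or untested is meant among the compounds shown, and "the series" means these compounds.

Two related compounds have been measured in a functional assay on Caco-2 cells (Homo sapiens), read by MTT assay, with a stated time of 48 h; on this read-out higher numbers stand for weaker inhibition and lower numbers for stronger inhibition. Compound 1 `CCn1c(C(=O)NCCN)ccc1C(CC)(CC)c1ccc(OCC(=O)C(C)(C)C)c(C)c1` gives 1900 nM, while compound 2 `CCOC(=O)CN(C)C(=O)c1ccc(C(CC)(CC)c2ccc(OCC(O)C(C)(C)C)c(C)c2)n1CC` gives 12200 nM, the higher number of the pair by a gap beyond the scatter, which makes compound 2 the weaker inhibitor of the two. Compound 3 `CCN(CC)CCCNC(=O)c1ccc(C(CC)(CC)c2ccc(OCC(O)C(C)(C)C)c(C)c2)n1CC` comes from compound 2 by a single change, ((3-(diethylamino)propyl)amino in place of ((ethoxycarbonyl)methyl)(methyl)amino on a carbonyl carbon), with (3-(diethylamino)propyl)amino in place of ((ethoxycarbonyl)methyl)(methyl)amino on a carbonyl carbon. Within the data shown here, no measured pair isolates this change, so its size remains uncertain. A step towards lower numbers, beyond the scatter, is expected: compound 1, whose amide also ends in an amino group, gives 1900 nM, though it differs from compound 3 elsewhere as well. The expected move is a 4.1-fold lower number from compound 2 to compound 3 (0.61 log units; beyond the scatter). The estimate for compound 3 is 3000 nM, within an expected range of 900 nM to 9000 nM.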

Compound 3, half-maximal inhibitory concentration: 1800 nM
Beside the measured number, compound 3's estimate is 1.7-fold (0.22 log units) above it, and the stated range covers the measured number.
By their numbers in this assay, from the lowest: compounds 3 and 1 (each within the scatter of the next); then compound 2.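

In this assay, the carbonyl carbon now has a measured step: (3-(diethylamino)propyl)amino in place of ((ethoxycarbonyl)methyl)(methyl)amino gives a 6.8-fold lower number from compound 2 to compound 3 (0.83 log units; beyond the scatter) on an otherwise unchanged compound. This shows that the group on this carbonyl carbon can by itself shift the number beyond the scatter, which compound 1 and compound 2 could not show, as they differ in more than one place. Nothing available here accounts for the size of this step.

The change removes the ester and brings in both an amide hydrogen and a diethylamino end, so the compounds shown do not separate the parts of the step. As far as these compounds go, it also remains open how a shorter chain ending in a primary amine, or a carboxylic acid in place of the ethyl ester, would read on this carbonyl carbon.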